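This account rests on a few compounds, and the source may have more. Where it says the series, first, only, none or still open, it means among the compounds named here.

Series of oxime ethers on a shared core. Compound 2 `CCCCCO/N=C/c1cc(OC)c2c(c1OC)C(=O)C=CC2=O` stands only at an assay limit: in a functional assay on A549 cells (Homo sapiens) for antiproliferative activity (a lower number here means that less compound is needed, a higher number that more compound is needed for the effect), compound 2 gives > 10 ug/mL, a limit of the assay rather than a number. Compound 1 `CCCCCCCO/N=C/c1cc(OC)c2c(c1OC)C(=O)C=CC2=O` likewise sits at a limit, giving > 10 ug/mL in this assay. Compound 3 `COc1cc(/C=N/OCc2ccccc2)c(OC)c2c1C(=O)C=CC2=O` also returns only a limit, > 10 ug/mL in this assay. Hence the steps among the three stay unreadable: a step that the two limits leave unreadable from compound 1 to compound 2, a step that the two limits leave unreadable from compound 1 to compound 3 and a step that the two limits leave unreadable from compound 2 to compound 3; every value shown sits at the limit of > 10 ug/mL in this assay, at which 3 of the 3 values shown sit.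

Compound 4 `CCCCCCCCCCCCO/N=C/c1cc(OC)c2c(c1OC)C(=O)C=CC2=O` carries heptyl in place of hydrogen on a saturated chain carbon, five bonds along the chain from an oxygen on an unsaturated carbon. Of the measured steps, a step that the two limits leave unreadable from compound 1 to compound 2 bears most directly on this move, being a change on the same saturated chain carbon five bonds along the chain from the oxygen; a step that the two limits leave unreadable from compound 2 to compound 3 and a step that the two limits leave unreadable from compound 1 to compound 3 alter the chain at the carbon bound to the oxygen instead. None of them yields a size or a direction. With nothing readable, no step beyond the scatter is expected in this assay from compound 2 to compound 4, and the most likely outcome is another limit. The estimate for compound 4 is 15 ug/mL, within 5 ug/mL to 60 ug/mL. The step this estimate means, a step that the limit leaves unreadable from compound 2 to compound 4, is expected to stay within the scatter.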

Compound 4, concentration for half-maximal effect: > 10 ug/mL
Compound 4: a limit, no number (the forecaster's own chance of this, stated with the estimate: 70%); the middle value lies beyond the limit too.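

In this assay compound 4 gives > 10 ug/mL, a limit and not a number. No step between compound 4 and compound 1 or compound 2 can be read, and every value shown is the same limit: the limit of > 10 ug/mL in this assay, at which 4 of the 4 values shown sit.

The compounds shown leave open whether any oxime ether on the shared core reaches a numerical value in this assay.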